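The source may report more compounds than this note shows. Statements on the series, on what has been measured and on what is new or still open speak of the compounds shown alone.

Measured in an ADME assay on Vero cells (Chlorocebus sabaeus) for cytotoxicity, with a stated time of 72 h; a higher number here means a weaker inhibitor, a lower number a stronger inhibitor:

compound 1, `CCOC(=O)c1cc(-c2cccc(OCc3ccccc3)c2)on1`: > 128000 nM, a limit of this assay.
compound 2, `CCOC(=O)c1cc(-c2cccc(OCc3ccccc3Cl)c2)on1`: > 128000 nM, a limit of this assay.
compound 3, `CCOC(=O)c1cc(-c2cccc(OCc3ccc(F)c(F)c3)c2)on1`: > 128000 nM, a limit of this assay.

Among the measured compounds shown here, compound 3 therefore stands at the limit of this assay rather than at a number, and every value so far sits there: the limit of > 128000 nM in this assay, at which 3 of the 3 values shown sit. The measured steps a step that the two limits leave unreadable from compound 1 to compound 2, a step that the two limits leave unreadable from compound 1 to compound 3 and a step that the two limits leave unreadable from compound 2 to compound 3 are all unreadable between two limits, so none of them gives a size.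

Compound 4, `CCOC(=O)c1cc(-c2cccc(OCc3cc(F)cc(F)c3)c2)on1`, differs from compound 3 by 3,5-difluorophenyl in place of 3,4-difluorophenyl on a saturated chain carbon bound to an oxygen on an aromatic ring. For the measured compounds named here, no measured step bears readably on this change, and nothing in this assay suggests a step beyond the scatter. For compound 4 the expected step is a step that the limit leaves unreadable from compound 3 to compound 4. Compound 4 is expected to give 150000 nM in this assay, between 60000 nM and 400000 nM, most likely reported again only as a limit.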

Compound 4, half-maximal inhibitory concentration: > 128000 nM
Compound 4: only a limit was reported; the forecaster's own chance of this, stated with the estimate: 85%; the middle value is on the limit's open side.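

Compound 4 is again only a limit, so its steps from compound 1, compound 2 and compound 3 cannot be read: the limit of > 128000 nM in this assay, at which 4 of the 4 values shown sit.

The compounds shown leave open whether the phenyl, 2-chlorophenyl, 3,4-difluorophenyl and 3,5-difluorophenyl groups differ at all in this assay.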